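Two limits and an untested step

A few compounds are considered here, and "the series" means these few. Any claim that something is new, unique, unknown or untested is made for them only; others in the source may bear on it.

Compound 1 (`Cc1[nH]c2ccccc2c(=O)c1Br`): > 42000 nM
Compound 2 (`CCCCC#Cc1c(C)[nH]c2ccc(OC)cc2c1=O`): > 36800 nM

In an ADME assay on J774 cells (Mus musculus) for cytotoxicity (a lower number here means that less compound is needed, a higher number that more compound is needed for the effect), compound 2 stands at a limit (> 36800 nM) and not at a number. Compound 1 likewise gives only a limit (> 42000 nM). Compound 3 (`CCCCC#Cc1c(C)[nH]c2ccccc2c1=O`) carries hydrogen in place of methoxy on an aromatic carbon. For the measured compounds named here, no measured pair shows this change, so the expected step (a step that the limit leaves unreadable from compound 2 to compound 3) is none beyond the scatter, and another limit is the likeliest report. In this assay the estimate for compound 3 is 40000 nM with an expected range from 15000 nM to 45000 nM for the measurement.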

Compound 3, half-maximal effective concentration: 8900 nM
Estimate against measurement, compound 3: 4.5-fold (0.65 log units) above, outside the stated range (below it).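

In this assay, for the compounds shown here, compound 3 is the first here to give a number and not a limit. Hydrogen in place of methoxy on an aromatic carbon brings an at least 4.1-fold lower number from compound 2 to compound 3 (0.61 log units; beyond the scatter) and hex-1-yn-1-yl in place of bromo brings an at least 4.7-fold lower number from compound 1 to compound 3 (0.67 log units; beyond the scatter) so both places matter for this effect. The first step is only a minimum, as compound 2 gives a limit: the limit of > 36800 nM in this assay, at which 1 of the 3 values shown sits.

As far as these compounds go, whether an amine on that aromatic carbon would behave like methoxy or like hydrogen stays open. So does whether a shorter chain such as but-1-yn-1-yl would keep the lower number.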